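Aryl replacement on the nitro-bearing core

The compounds below may be only part of what the source reports. "The series", "measured", "known", "first", "only" and "open" are said of these compounds alone.

Measured so far:
- compound 1 `O=[N+]([O-])c1cc2c(OCCC3CCCCN3)c(-c3cccs3)c(O)nc2cc1Cl`: 220 nM
- compound 2 `O=C(Nc1cc2c(OCCC3CCCCN3)c(-c3cccc(Br)c3)c(O)nc2cc1Cl)NC1CC1`: 6 nM
- compound 3 `Cc1cc(C)cc(-c2c(O)nc3cc(Cl)c(NC(=O)Nc4ncccn4)cc3c2OCCC2CCCCN2)c1`: 6 nM

In a functional assay on cells (Pituitary gland cell) for antagonist activity at Gonadotropin-releasing hormone receptor (Rattus norvegicus) (a higher number here means a weaker inhibitor, a lower number a stronger inhibitor), compound 1 gives 220 nM, the highest of the three numbers; compound 2 and compound 3 both lie well below it, beyond the scatter. Compound 2 and compound 3 also differ from compound 1 in the urea group, so the aryl contribution alone cannot be separated from the numbers shown.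

Compound 4 `CC(=O)OCc1cc(C)cc(-c2c(O)nc3cc(Cl)c([N+](=O)[O-])cc3c2OCCC2CCCCN2)c1` keeps the nitro group of compound 1 and differs from it only by 3-(acetoxymethyl)-5-methylphenyl in place of thiophen-2-yl on an aromatic carbon. Among the measured compounds shown here, no step of this kind is measured. Going from compound 1 the expectation is a modest drop in the number, a step of a 3.7-fold lower number from compound 1 to compound 4 (0.56 log units; beyond the scatter), guided by the low values of compound 2 and compound 3 on aryl-substituted cores. For compound 4 the estimate is 60 nM, within 15 nM to 250 nM.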

Compound 4, half-maximal inhibitory concentration: 45 nM
Estimate against measurement, compound 4: 1.3-fold (0.12 log units) above; the range from low to high includes it.
By their numbers in this assay, from the lowest: compounds 2 and 3 (each within the scatter of the next); then compound 4; then compound 1.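

With the nitro group held, the change of thiophen-2-yl to 3-(acetoxymethyl)-5-methylphenyl in this assay gives a 4.9-fold lower number from compound 1 to compound 4 (0.69 log units; beyond the scatter) as a step beyond the scatter. Among the compounds shown here, compound 2 and compound 3 also carry a urea, so this is the only reading of this position in which the aryl group changes alone. No measurement in hand accounts for the step.

As far as these compounds go, whether the six-membered ring or its acetoxymethyl group carries the step stays open; unsubstituted phenyl, or hydroxymethyl in place of acetoxymethyl, on this core would separate the two. From the compounds shown here alone, whether the step carries over to urea-bearing cores also stays open.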